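The source may hold more compounds than are shown below. What is called first, only, known or untested is meant among the compounds shown, and "the series" means these compounds.

For the measured compounds named here, compound 3 `Fc1ccc(-c2cc(-c3ccc4cc(F)ccc4n3)n(-c3ccccc3)n2)cc1` stands lowest of the three numbers known so far in an ADME assay on Huh-7 cells (Homo sapiens) for cytotoxicity, read by XTT assay, with a stated time of 3 days, tested at 20 uM (a lower number here means a stronger effect, a higher number a weaker effect of the compound at the concentration tested), where compound 3 gives 88.1%. Compound 1 `Fc1ccc2nc(-c3cc(-c4ccccc4)n(-c4ccccc4)n3)ccc2c1` gives 124% in this assay, and compound 2 `Fc1ccc2nc(-c3cc(-c4ccccc4)nn3-c3ccccc3)ccc2c1` gives 126%; these two lie within the scatter of each other, and compound 3 sits beyond the scatter below both. Going by the values given here, the only step between measured compounds that differ in one place is a number 37.9 percentage points lower from compound 2 to compound 3 (beyond the scatter), a large drop that came with a fluoro entering an aromatic ring. Compound 4 `COc1ccc(-c2cc(-c3ccc4cc(F)ccc4n3)n(-c3ccccc3)n2)cc1` differs from compound 3 by methoxy in place of fluoro on an aromatic carbon. Among the compounds with values here, no measured step involves a methoxy entering or a fluoro leaving, so the one known step bears on this change only loosely: it shows that a single substituent swap on this outer ring can move the number beyond the scatter, but not in which direction a methoxy would move it. He therefore expects a step of a number 11.9 percentage points higher from compound 3 to compound 4 (beyond the scatter), modest and uncertain in sign. For compound 4 he estimates 100%, with a range from 72% to 128%.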

Compound 4, a percentage reported as activity, at one concentration (the size of the read-out at that concentration, not a potency): 104%
The estimate for compound 4 lay 4 percentage points below the measured number, and the stated range covers the measured number.
By their numbers in this assay, from the lowest: compound 3; then compound 4; then compounds 1 and 2 (each within the scatter of the next).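

In this assay, for the compounds shown here, the swap from 4-fluorophenyl to 4-methoxyphenyl now has a direction, with a number 15.9 percentage points higher from compound 3 to compound 4 (beyond the scatter) as the step that the earlier compounds could not supply. Measured against the compound with hydrogen at this place, the methoxy also counts on its own, giving a number 22 percentage points lower from compound 2 to compound 4 (beyond the scatter) in a series where the fluoro gives a number 37.9 percentage points lower from compound 2 to compound 3 (beyond the scatter) on the same aromatic carbon, so both groups lower the number and the fluoro lowers it more. Nothing among the data shown explains these steps.

On these data alone, whether an amine, a carboxylic acid or a longer chain at this place would also lower the number stays open. So does whether a fluoro or a methoxy would act in the same way on the core of compound 1.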